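Solubility of an oxazolidinone pair and a ring-carbon amide

The source may hold more compounds than are shown below. What is called first, only, known or untested is meant among the compounds shown, and "the series" means these compounds.

Measured compounds:
compound 1 `O=C1O[C@@H](CSc2cccs2)CN1c1ccc(-n2cc(-c3ccccn3)cn2)c(F)c1` gives 8500 nM
compound 2 `COC(=O)NC[C@H]1CN(c2ccc(-n3cc(-c4ccccn4)cn3)c(F)c2)C(=O)O1` gives 34100 nM

Among the measured compounds shown here, in a physicochemical assay for solubility, read by HPLC, with a stated time of 24 h (on this read-out lower numbers stand for lower solubility and higher numbers for higher solubility), compound 2 holds the higher of the two numbers measured so far; its nearest neighbour is compound 1, and the step of a 4.0-fold higher number from compound 1 to compound 2 (0.60 log units; beyond the scatter) is a modest one that lies beyond the scatter. Compound 3 `CONC(=O)[C@H]1CN(c2ccc(-n3cc(-c4ccccn4)cn3)c(F)c2)C(=O)O1` has not yet been measured. It differs from compound 2 in a single place: methoxycarbamoyl in place of ((methoxycarbonyl)amino)methyl on a saturated ring carbon. For the measured compounds named here, only one measured step exists in this set, and it concerns the exchange of (thiophen-2-yl)sulfanyl for (methoxycarbonyl)amino on the chain carbon; the change from compound 2 to compound 3 is of a different kind, so no measured step bears on it directly. With nothing to anchor a direction, a step of no more than the usual scatter is expected, and the estimate for compound 3 follows as a 1.1-fold lower number from compound 2 to compound 3 (0.06 log units; within the scatter). Compound 3 is therefore expected to give about 30000 nM in this assay, within a range of 12000 nM to 75000 nM.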

Compound 3, solubility: 78100 nM
Beside the measured number, compound 3's estimate is 2.6-fold (0.42 log units) below it; the whole stated range lies below it.
By their numbers in this assay, from the lowest: compound 1; then compound 2; then compound 3.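

In this assay, methoxycarbamoyl in place of ((methoxycarbonyl)amino)methyl on the saturated ring carbon next to the ring oxygen gives a 2.3-fold higher number from compound 2 to compound 3 (0.36 log units; beyond the scatter). The number at this position therefore still moves beyond the scatter when the two groups have the same printed counts of 1 hydrogen-bond donor and 2 hydrogen-bond acceptors, with no ring and no net charge, and differ by 5 heavy atoms entering for 6 leaving. The earlier step changed only what hung on the saturated chain carbon, whereas this change removes that chain carbon from the group, and the replacement of ((thiophen-2-yl)sulfanyl)methyl by methoxycarbamoyl gives a 9.2-fold higher number from compound 1 to compound 3 (0.96 log units; beyond the scatter), which places compound 3 above both other compounds by steps beyond the scatter.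

The compounds shown leave open how an amine, a carboxylic acid or a plain carboxamide on the same saturated ring carbon would compare, and whether a longer chain between that carbon and the methoxycarbamoyl group would keep the higher number. Nothing in hand beyond these three numbers speaks to what lies behind the steps.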